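Loss of the ((tert-butyl)carbonyl)oxy group: compound 4

This account rests on a few compounds, and the source may have more. Where it says the series, first, only, none or still open, it means among the compounds named here.

Compound 2 `CC(OC(=O)N1CCN(C(=O)c2nc(Nc3cc(C4CC4)[nH]n3)c3cc(Cl)ccc3n2)C[C@H]1C)OC(=O)C(C)(C)C` stands second highest of the three compounds measured in an ADME assay on a cell-free system (plasma, Homo sapiens), read by HPLC, with a stated time of 120 min, at 37 degrees C (on this read-out lower numbers stand for a less stable compound and higher numbers for a more stable compound), where compound 2 gives 49.4%. Compound 3 `C[C@@H]1CN(C(=O)c2nc(Nc3cc(C4CC4)[nH]n3)c3cc(Cl)ccc3n2)CCN1C(=O)OCc1ccccc1` gives 86.2%, while compound 1 `CC(C)C(=O)OCOC(=O)N1CCN(C(=O)c2nc(Nc3cc(C4CC4)[nH]n3)c3cc(Cl)ccc3n2)C[C@H]1C` gives 6.1%. Compound 4 `CCOC(=O)N1CCN(C(=O)c2nc(Nc3cc(C4CC4)[nH]n3)c3cc(Cl)ccc3n2)C[C@H]1C` differs from compound 2 by hydrogen in place of ((tert-butyl)carbonyl)oxy on a saturated chain carbon bound to an oxygen next to a carbonyl group and a saturated chain carbon. Going by the values given here, the steps that bear on this are those in which the ((isopropylcarbonyl)oxy) or ((tert-butyl)carbonyl)oxy group is lost from the group on the oxygen next to the carbonyl: a number 36.8 percentage points higher from compound 2 to compound 3 (beyond the scatter) and a number 80.1 percentage points higher from compound 1 to compound 3 (beyond the scatter), both large rises. Compound 4 is therefore expected to rise strongly in this assay, toward the level of compound 3, with an estimated step of a number 35.6 percentage points higher from compound 2 to compound 4 (beyond the scatter). Compound 4 is estimated at 85%, within a range of 65% to 98%.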

Compound 4, percent of the compound remaining: 85.3%
Compound 4: middle estimate off by 0.3 percentage points, on the low side; measured number inside the range.
By their numbers in this assay, from the lowest: compound 1; then compound 2; then compounds 4 and 3 (each within the scatter of the next).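

In this assay, the plain ethoxycarbonyl group, without ((tert-butyl)carbonyl)oxy, gives a number 35.9 percentage points higher from compound 2 to compound 4 (beyond the scatter), and without the (isopropylcarbonyl)oxy group it gives a number 79.2 percentage points higher from compound 1 to compound 4 (beyond the scatter). The phenyl of compound 3 is not needed to reach this level, since methyl in its place gives a number 0.9 percentage points lower from compound 3 to compound 4 (within the scatter). No supporting data explain this result.

Still open, on these data alone, is whether an amine, a carboxylic acid or a longer chain on this saturated chain carbon would keep the number at this level. The separate contributions of the added methyl and the tert-butyl within the acyloxy groups also remain unresolved.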